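The compounds below may be only part of what the source reports. "The series", "measured", "known", "first", "only" and "open" are said of these compounds alone.

Of the compounds shown here, two have so far been measured in an assay on HEK293 cells for displacement of a labelled ligand from NPC1-like intracellular cholesterol transporter 1 (Homo sapiens); on this read-out lower numbers stand for stronger inhibition and higher numbers for weaker inhibition. Compound 1, `CC(C)(C)OC(=O)NC1CCCN(C(=O)CN2CN(c3ccccc3)C3(CCN(C(=O)c4ccc(C5CCCCC5)cc4)CC3)C2=O)C1`, gives 4400 nM. Compound 2, `CCC1CCCN(C(=O)CN2CN(c3ccccc3)C3(CCN(C(=O)c4ccc(C(C)(C)C)cc4)CC3)C2=O)C1`, gives 3900 nM. Compound 2 carries the lower of the two numbers, yet its gap to compound 1 lies within the usual scatter, so the two values cannot be told apart. For the measured compounds named here, no step between two measured compounds that differ in a single place is available, so nothing yet shows how a change at one spot of the shared core moves the read-out.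

Compound 3, `CC(C)(C)c1ccc(C(=O)N2CCC3(CC2)C(=O)N(CC(=O)N2CCCC(O)C2)CN3c2ccccc2)cc1`, differs from compound 2 in one place: hydroxy in place of ethyl on a saturated ring carbon. The change sits on a saturated ring carbon of a six-membered non-aromatic ring with 1 nitrogen, two ring bonds from the ring nitrogen, turning the 3-ethylpiperidin-1-yl group into a 3-hydroxypiperidin-1-yl group. Going by the values given here, the measured pair offers no step to lean on for this kind of change. The step of a 1.3-fold higher number from compound 2 to compound 3 (0.11 log units; within the scatter) is therefore expected to be small, with no clear direction beyond the scatter. The estimate for compound 3 is 5000 nM, with a range from 1500 nM to 16000 nM.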

Compound 3, half-maximal inhibitory concentration: 12200 nM
For compound 3 the middle estimate is 2.4-fold (0.39 log units) below the measured one, within the range that was stated.
By their numbers in this assay, from the lowest: compounds 2 and 1 (each within the scatter of the next); then compound 3.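

In this assay, for the compounds shown here, turning the 3-ethylpiperidin-1-yl group into a 3-hydroxypiperidin-1-yl group gives a 3.1-fold higher number from compound 2 to compound 3 (0.50 log units; beyond the scatter) as the first change at a single place in this set, a modest step but a real one. It shows that this saturated ring carbon, two ring bonds from the ring nitrogen, is not indifferent to what it carries: the swap of ethyl for hydroxy, which brings one hydrogen-bond donor and one hydrogen-bond acceptor where ethyl counted none, goes with weaker inhibition. Nothing at hand gives a reason for this rise in the number.

On these data alone, a single step cannot separate the arrival of the hydroxy from the departure of the ethyl, so it stays open whether the rise follows the one or the other. A plain ring carbon with only hydrogen, a methyl, a longer chain such as propyl, a methoxy or an amine at this same carbon would help to tell these apart, and would show whether ethyl is itself better than no group at all.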